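Diethylamino in place of phenyl: notes on compound 3

This account rests on a few compounds, and the source may have more. Where it says the series, first, only, none or still open, it means among the compounds named here.

Measured so far in a functional assay on SK-OV-3 cells (Homo sapiens) for antiproliferative activity, read by MTT assay, with a stated time of 24 h (on this read-out lower numbers stand for stronger inhibition and higher numbers for weaker inhibition), with both values being limits:
Compound 1 `COc1ccc(C(=O)/C=C/c2ccc(F)cc2)c2c1C=CC(C)(C)O2` gives > 10000 nM as a limit
Compound 2 `COc1ccc(C(=O)/C=C/c2ccc(-c3ccccc3)cc2)c2c1C=CC(C)(C)O2` gives > 10000 nM as a limit

Among the measured compounds shown here, compound 2 has no number of its own, and the series so far is described only by the limit of > 10000 nM in this assay, at which 2 of the 2 values shown sit, and nothing finer. The next structure is compound 3 `CCN(CC)c1ccc(/C=C/C(=O)c2ccc(OC)c3c2OC(C)(C)C=C3)cc1` and its difference from compound 2 is diethylamino in place of phenyl on an aromatic carbon in one swap: diethylamino in place of phenyl on an aromatic carbon, para to a large group.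

For the measured compounds named here, only one measured step bears on this swap, namely a step that the two limits leave unreadable from compound 1 to compound 2 with phenyl in place of fluoro on an aromatic carbon. Its size cannot be read, so it offers no magnitude or direction to carry over. In this assay no step beyond the scatter can be argued from these data, and compound 3 is expected to stay at the limit, though a readable value remains possible. This expectation rests on compound 2 with > 10000 nM which is a limit. The expected step is a step that the limit leaves unreadable from compound 2 to compound 3 and is an estimate only. For compound 3 the estimated value is 12000 nM with an expected range from 3000 nM to 40000 nM in this estimate.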

Compound 3, half-maximal inhibitory concentration: 610 nM
Compound 3: middle estimate off by 20-fold (1.29 log units), on the high side, and the stated range ends above it.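

In this assay, the aromatic carbon para to a large group turns out to be a place where one swap moves the series off its limit: diethylamino in place of phenyl gives an at least 16-fold lower number from compound 2 to compound 3 (1.21 log units; beyond the scatter), and diethylamino in place of fluoro gives an at least 16-fold lower number from compound 1 to compound 3 (1.21 log units; beyond the scatter). Fluoro and phenyl alone had shown nothing of this, since the step between those two limits cannot be read, and the new steps are themselves minimum sizes because each starts from a limit. Compound 3 is thus the only compound shown with a readable value, and the other two remain limits: the limit of > 10000 nM in this assay, at which 2 of the 3 values shown sit.

The compounds shown leave open whether the gain depends on the nitrogen itself or on the two ethyl chains attached to it, which a dimethylamino group, a pyrrolidine ring or a morpholine ring at the same carbon would begin to separate from a plain butyl chain. They also leave open whether a methoxy group or a primary amine at that carbon would give a readable value at all.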